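Homologating the pyrrolidine amide on a piperidine-linked core

This account rests on a few compounds, and the source may have more. Where it says the series, first, only, none or still open, it means among the compounds named here.

Compound 1 `Cc1nn([C@H](C)c2ccc(Cl)cc2Cl)c2nc(N3CC[C@H](N4CCC[C@H]4C(N)=O)[C@H](C)C3)cnc12` carries a 2-carbamoylpyrrolidin-1-yl group on the piperidine that hangs from the shared core, and in an assay on CCRF-CEM cells for antagonist activity at C-C chemokine receptor type 4 (Homo sapiens), read by CellTiter-Glo, with stated times of 30 min and 60 min, in the presence of a further agent that is not named here (on this read-out higher numbers stand for weaker inhibition and lower numbers for stronger inhibition), compound 1 is recorded as "not determined" (no result reported), with no number reported. Two related compounds give context. Compound 2 `Cc1nn([C@H](C)c2ccc(Cl)cc2Cl)c2nc(N3CC[C@H](N4CCC4)[C@H](C)C3)cnc12`, with an azetidine in place of the pyrrolidine, gives 218 nM in this assay. Compound 3 `C[C@@H]1CC(c2cnc3c(C#N)nn([C@H](C)c4ccc(Cl)cc4Cl)c3n2)=CC[C@@H]1N1CCC[C@H]1CO`, built on a different ring linker and bearing a hydroxymethyl on its pyrrolidine, gives 70 nM in this assay. Compound 4 `Cc1nn([C@H](C)c2ccc(Cl)cc2Cl)c2nc(N3CC[C@H](N4CCC[C@H]4CCC(N)=O)[C@H](C)C3)cnc12` differs from compound 1 by the change (2-carbamoylethyl in place of carbamoyl on a saturated ring carbon), that is, 2-carbamoylethyl in place of carbamoyl on a saturated ring carbon. Going by the values given here, no measured step between compounds differing only in this way is available, and compound 1 itself has no number, so the size of the step cannot be inferred; a change within the usual scatter, in either direction, seems the most defensible expectation. On the two measured neighbours, compound 4 is expected to give about 130 nM in this assay, within a range of 30 nM to 600 nM.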

Compound 4, half-maximal inhibitory concentration: 355 nM
Estimate against measurement, compound 4: 2.7-fold (0.44 log units) below; the range from low to high includes it.
By their numbers in this assay, from the lowest: compound 3; then compounds 2 and 4 (each within the scatter of the next).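

In this assay, putting 2-(2-carbamoylethyl)pyrrolidin-1-yl in place of azetidin-1-yl on the piperidine gives a 1.6-fold higher number from compound 2 to compound 4 (0.21 log units; within the scatter). Going by these compounds alone, this is the first measured number for a substituted pyrrolidine on this piperidine-linked core, and it shows that the 2-carbamoylethyl chain on the ring carbon can be carried with no change beyond the scatter relative to the plain azetidine of compound 2. Nothing measured here bears on why the two compounds read alike.

The step from carbamoyl to 2-carbamoylethyl itself cannot be read, since compound 1 has no number. Also open, from the compounds shown here alone, is how this position would respond if the amide at the end of the chain gave way to a carboxylic acid or a primary amine, or if the chain were extended to 3-carbamoylpropyl.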